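Sulfonyl aryl swap on a shared core: compound 4

The compounds below may be only part of what the source reports. "The series", "measured", "known", "first", "only" and "open" are said of these compounds alone.

Compound 1 `COc1ccc(-c2cc(=O)c3c(OC)cc(OC)cc3n2S(=O)(=O)c2ccc(C)c([N+](=O)[O-])c2)cc1`: > 51700 nM
Compound 2 `COc1ccc(-c2cc(=O)c3c(OC)cc(OC)cc3n2S(=O)(=O)c2ccc(F)cc2)cc1`: > 65500 nM
Compound 3 `COc1ccc(-c2cc(=O)c3c(OC)cc(OC)cc3n2S(=O)(=O)c2cc(Cl)cc(Cl)c2O)cc1`: > 37900 nM

In an ADME assay on BJ cells (Homo sapiens) for antiproliferative activity, with a stated time of 72 h (on this read-out lower numbers stand for an effect already at smaller amounts and higher numbers for an effect only at larger amounts of compound), compound 3 gives > 37900 nM, which is a limit of the assay and not a number. Compound 1 likewise gives > 51700 nM, a limit. Compound 2 gives > 65500 nM, again a limit. Compound 3 therefore stands among three values that are all limits (the limit of > 37900 nM in this assay, at which 1 of the 3 values shown sits, (the limit of > 51700 nM in this assay, at which 1 of the 3 values shown sits), (the limit of > 65500 nM in this assay, at which 1 of the 3 values shown sits)), so none of the three can be ordered against another.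

Compound 4 `COc1ccc(-c2cc(=O)c3c(OC)cc(OC)cc3n2S(=O)(=O)c2ccc(OC)cc2)cc1` carries the change (4-methoxyphenyl in place of 3,5-dichloro-2-hydroxyphenyl on a sulfonyl sulfur). The measured steps that bear on it are a step that the two limits leave unreadable from compound 1 to compound 3, a step that the two limits leave unreadable from compound 2 to compound 3 and a step that the two limits leave unreadable from compound 1 to compound 2; each is left unreadable by the two limits, so no step size beyond the scatter can be read from them. Compound 4 is expected to give 60000 nM, within 30000 nM to 120000 nM, most probably again only as a limit. This estimate means a step that the limit leaves unreadable from compound 3 to compound 4, expected to lie within the scatter.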

Compound 4, half-maximal effective concentration: > 82700 nM
Compound 4 ended at the assay's limit; the forecaster's own chance of this, stated with the estimate: 80%; middle value at least 1.3-fold (0.13 log units) away from the limit.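

In this assay compound 4 gives > 82700 nM, which is a limit. The steps from compound 1, compound 2 and compound 3 to compound 4 cannot be read. The compounds shown leave open whether any of these aryl groups on the sulfonyl sulfur changes the read-out in this assay.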